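A few compounds are considered here, and "the series" means these few. Any claim that something is new, unique, unknown or untested is made for them only; others in the source may bear on it.

The measured compounds:
compound 1 `COc1cc(C)c(C(=O)O[C@H]2[C@@H](O)[C@@H](O)[C@H](O[C@H]3CC[C@H](C)[C@@H]4[C@@H]3C=C(C)[C@H]3/C(C)=C/CC/C(C)=C/[C@@H]5C=C(C(=O)O)[C@H](C)C[C@]56OC(=O)C(=C6O)C(=O)[C@@]43C)O[C@@H]2C)c(O)c1` — in a toxicity assay on NCI-H460 cells (Homo sapiens) for cytotoxicity, read by MTT assay, with a stated time of 48 h (on this read-out lower numbers stand for stronger inhibition and higher numbers for weaker inhibition), compound 1 gives > 30000 nM, which is a limit of the assay.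
compound 2 `COc1cc(C)c(C(=O)O[C@H]2[C@@H](O)[C@H](O[C@H]3CC[C@H](C)[C@@H]4[C@@H]3C=C(C)[C@H]3/C(C)=C/CC/C(C)=C/[C@]5(C)C=C(C(=O)O)[C@H](C)C[C@]56OC(=O)C(=C6O)C(=O)[C@@]43C)O[C@H](C)[C@H]2O)c(O)c1` — in this assay compound 2 gives > 30000 nM, also a limit of the assay.
compound 3 `CC1=C[C@@]2(C)/C=C(\C)CC/C=C(\C)[C@@H]3C(C)=C[C@H]4[C@@H]([C@@H](C)CC[C@@H]4O)[C@]3(C)C(=O)C3=C(O)[C@@]2(C[C@H]1C)OC3=O` — in this assay compound 3 gives > 30000 nM, again a limit of the assay.

Compound 3 therefore does not stand at any particular number in this assay; it sits at the limit, as do the other two compounds, and nothing separates any of the three from the others. For the measured compounds named here, the only evidence to lean on is the limit of > 30000 nM in this assay, at which 3 of the 3 values shown sit.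

Compound 4 `CC(=O)O[C@H]1CC[C@H](C)[C@@H]2[C@@H]1C=C(C)[C@H]1/C(C)=C/CC/C(C)=C/[C@]3(C)C=C(C)[C@H](C)C[C@]34OC(=O)C(=C4O)C(=O)[C@@]21C` is the unmeasured partner of compound 3. The difference between the two is acetyl in place of hydrogen on an oxygen on a saturated carbon. Going by the values given here, no step between measured compounds has been observed, so there is no measured precedent for what acetyl in place of hydrogen on an oxygen on a saturated carbon does here. With every shown value at the limit, the expected step in this assay from compound 3 to compound 4 is none beyond the scatter, and the most likely outcome is another limit rather than a number. The estimate for compound 4 is 30000 nM, within 8000 nM to 100000 nM, which corresponds to an expected step of a number no higher from compound 3 to compound 4 (the limit leaves the size open).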

Compound 4, half-maximal inhibitory concentration: > 30000 nM
Compound 4: no number, only a limit (the forecaster's own chance of this, stated with the estimate: 75%); the middle value lies on the limit itself.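

In this assay compound 4 gives > 30000 nM, a limit of the assay. Compound 3 stands at a limit too, so no step can be read between compound 3 and compound 4. The compounds shown leave open whether acetyl in place of hydrogen on an oxygen on a saturated carbon changes the read-out at all, and what number any of the four compounds would reach.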